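A few compounds are considered here, and "the series" means these few. Any claim that something is new, unique, unknown or untested is made for them only; others in the source may bear on it.

Of the compounds shown here, three sharing one core have been measured in an ADME assay on a cell-free system (plasma, Mus musculus) for protein binding. Compound 1 `CNc1nccc(N2CC[C@H](NC(=O)Nc3ccc(Cl)c(C(F)(F)F)c3)C2)n1`, which carries chloro, gives 99.8%. Compound 2 `CNc1nccc(N2CC[C@H](NC(=O)Nc3ccc(CN4CCCC4)c(C(F)(F)F)c3)C2)n1`, with (pyrrolidin-1-yl)methyl in its place, gives 87.2%, and compound 3 `CCN1CCN(Cc2ccc(NC(=O)N[C@H]3CCN(c4ccnc(NC)n4)C3)cc2C(F)(F)F)CC1`, with (4-ethylpiperazin-1-yl)methyl there, gives 85.4%. Compound 3 thus stands at the free end of this small set, level with compound 2 and far from compound 1. The exchange of the two amine groups, a 1.1-fold higher unbound fraction from compound 2 to compound 3 (0.06 log units; within the scatter), lies within the scatter, whereas the replacements of chloro gave large steps, a 64-fold higher unbound fraction from compound 1 to compound 2 (1.81 log units; beyond the scatter) and a 73-fold higher unbound fraction from compound 1 to compound 3 (1.86 log units; beyond the scatter).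

Compound 4 `CNc1nccc(N2CC[C@H](NC(=O)Nc3ccc(CN4CCN(C)CC4)c(C(F)(F)F)c3)C2)n1` differs by a single change, hydrogen in place of methyl on a saturated chain carbon bound to an amine nitrogen in a ring, so that 4-ethylpiperazin-1-yl becomes 4-methylpiperazin-1-yl. For the measured compounds named here, no measured step makes this exact change. The large steps concern the loss of chloro, which plays no part here. The closest evidence is a 1.1-fold higher unbound fraction from compound 2 to compound 3 (0.06 log units; within the scatter), a bigger exchange that stayed within the scatter. No shift beyond the scatter is therefore expected in this assay, and the expected step is a 1.0-fold higher unbound fraction from compound 3 to compound 4 (0.01 log units; within the scatter). The estimate for compound 4 is 85%, expected to fall between 76% and 92%.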

Compound 4, plasma protein binding: 85.8%
The estimate for compound 4 lay 1.1-fold (0.02 log units) (unbound fraction) above the measured number; low and high end bracket the measured number.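

In this assay, the direct exchange of ethyl for methyl within the 4-ethylpiperazin-1-yl group gives a result within the scatter (a 1.0-fold lower unbound fraction from compound 3 to compound 4 (0.01 log units; within the scatter)), so this shortening of the chain on the ring amine nitrogen leaves the read-out in place for this pair. Compound 4 also stays level with the pyrrolidin-1-yl compound (a 1.1-fold higher unbound fraction from compound 2 to compound 4 (0.05 log units; within the scatter)) and keeps the full distance from the chloro compound (a 71-fold higher unbound fraction from compound 1 to compound 4 (1.85 log units; beyond the scatter)), so all three amine groups now sit together, well apart from chloro, with no listed compound going against that grouping. No independent measurement is available to say why these three groups read alike in this assay.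

The compounds shown leave open whether the level holds with an open-chain amine such as (dimethylamino)methyl, or with the unsubstituted piperazin-1-yl group, which carries hydrogen in place of the methyl of compound 4. They also leave open whether a carboxylic acid at the position of chloro would fall with these amines or apart from them, and whether the methylene link between the amine and the aromatic carbon could be lengthened to a longer chain without moving the read-out.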